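This account rests on a few compounds, and the source may have more. Where it says the series, first, only, none or still open, it means among the compounds named here.

In an in vivo functional assay on the whole organism for inhibition, with Rattus norvegicus as the target (on this read-out higher numbers stand for an effect only at larger amounts of compound and lower numbers for an effect already at smaller amounts), compound 3 (`CCCCc1nc(C)c(CC(=O)N2CCOCC2)c(=O)n1Cc1ccc(-c2ccccc2-c2nnn[nH]2)cc1`) gives 0.018 mg/kg. Compound 2 (`CCCCc1nc(C)c(CC(=O)N(C)C)c(=O)n1Cc1ccc(-c2ccccc2-c2nnn[nH]2)cc1`) stands level with it at 0.018 mg/kg, and together they hold the lowest number of the three, while compound 1 (`CCCCc1nc(C)c(CCC(=O)OCC)c(=O)n1Cc1ccc(-c2ccccc2-c2nnn[nH]2)cc1`) gives 0.066 mg/kg. Compound 4 (`CCCCc1nc(C)c(CCC(=O)N2CCOCC2)c(=O)n1Cc1ccc(-c2ccccc2-c2nnn[nH]2)cc1`) differs from compound 3 in one place: ((morpholin-4-yl)carbonyl)methyl in place of (morpholin-4-yl)carbonyl on a saturated chain carbon bound to an aromatic carbon. Here ((morpholin-4-yl)carbonyl)methyl stands in place of (morpholin-4-yl)carbonyl on a saturated chain carbon bound to an aromatic carbon. Going by the values given here, no measured step isolates this change. The step of no change at the digits printed from compound 2 to compound 3 (within the scatter) concerns only the amine on the carbonyl carbon. The two modest steps, a 3.7-fold lower number from compound 1 to compound 3 (0.56 log units; beyond the scatter) and a 3.7-fold lower number from compound 1 to compound 2 (0.56 log units; beyond the scatter), shorten the chain and replace the ethoxycarbonyl end together, so they offer only a rough upper guide. Compound 4 keeps the chain length of compound 1 but not its ester end, so part of that size, towards a higher number, is expected. The expected change is a 1.7-fold higher number from compound 3 to compound 4 (0.22 log units; within the scatter), which may not clear the scatter. Compound 4 is estimated at 0.03 mg/kg, with an expected range from 0.012 mg/kg to 0.08 mg/kg.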

Compound 4, dose for half-maximal effect: 0.143 mg/kg
The estimate for compound 4 lay 4.8-fold (0.68 log units) below the measured number, outside the stated range (above it).
By their numbers in this assay, from the lowest: compounds 2 and 3 (each within the scatter of the next); then compound 1; then compound 4.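

In this assay, one added chain carbon on the morpholine amide, with the amine end held the same, gives a 7.9-fold higher number from compound 3 to compound 4 (0.90 log units; beyond the scatter), which shows that chain length at this position matters on its own. The step to the same longer chain from the dimethylamide is equally large, a 7.9-fold higher number from compound 2 to compound 4 (0.90 log units; beyond the scatter), although it changes the amine as well. On the longer chain, the end group also counts: morpholin-4-yl in place of ethoxy on the carbonyl carbon gives a 2.2-fold higher number from compound 1 to compound 4 (0.34 log units; beyond the scatter), so an amide end on this chain does not by itself give the low numbers of compound 2 and compound 3.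

Nothing at hand explains why a single chain carbon shifts the dose this far. The compounds shown leave open how a carboxylic acid at the chain end, or a still longer chain carrying the morpholine amide, would read.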